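From 3-bromophenyl to 4-hydroxyphenyl on a shared core

The compounds below may be only part of what the source reports. "The series", "measured", "known", "first", "only" and "open" are said of these compounds alone.

Measured in a functional assay on A549 cells (Homo sapiens) for inhibition, read by CCK-8 assay, with a stated time of 72 h, tested at 1 uM; a higher number here means more inhibition of growth at the concentration tested, a lower number less inhibition of growth:
compound 1 `CN(C)C(=O)c1cc2cnc(Nc3ccc(NC(=O)C4(C(=O)Nc5ccc(F)cc5)CC4)cc3)nc2n1C1CCCC1`: 86.6%
compound 2 `Cc1ccc(NC(=O)C2(C(=O)Nc3ccc(Nc4ncc5cc(C(=O)N(C)C)n(C6CCCC6)c5n4)cc3)CC2)cc1`: 40.2%
compound 3 `CN(C)C(=O)c1cc2cnc(Nc3ccc(NC(=O)C4(C(=O)Nc5cccc(Br)c5)CC4)cc3)nc2n1C1CCCC1`: 20.2%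

Of these three, compound 3 stands lowest, and the gaps to both others lie beyond the scatter. Compound 4 `CN(C)C(=O)c1cc2cnc(Nc3ccc(NC(=O)C4(C(=O)Nc5ccc(O)cc5)CC4)cc3)nc2n1C1CCCC1` has not yet been measured. It keeps the shared core and changes one group: 4-hydroxyphenyl in place of 3-bromophenyl on an amide-type nitrogen. In words, this is 4-hydroxyphenyl in place of 3-bromophenyl on an amide-type nitrogen.

For the measured compounds named here, two measured steps bear most directly on this change, since both arrive at the 3-bromophenyl group. With 3-bromophenyl in place of 4-fluorophenyl, the result was a number 66.4 percentage points lower from compound 1 to compound 3 (beyond the scatter), a large step. With 3-bromophenyl in place of 4-methylphenyl, it was a number 20 percentage points lower from compound 2 to compound 3 (beyond the scatter), a modest one. Read in reverse, both suggest that leaving the 3-bromophenyl group for a 4-substituted phenyl raises the number. Going by the values given here, the size remains open, however, as a number 46.4 percentage points lower from compound 1 to compound 2 (beyond the scatter) separates the two 4-substituted groups by a large margin, and no hydroxyphenyl compound has been measured. A rise of modest to large size is therefore expected in this assay, estimated as a number 29.8 percentage points higher from compound 3 to compound 4 (beyond the scatter). For compound 4 the expected value is 50%, with an estimated range of 20% to 85%.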

Compound 4, percent growth inhibition at one concentration: 93.6%
Beside the measured number, compound 4's estimate is 43.6 percentage points below it, outside the stated range (above it).
By their numbers in this assay, from the lowest: compound 3; then compound 2; then compounds 1 and 4 (each within the scatter of the next).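

In this assay, the change on the amide-type nitrogen gives a number 73.4 percentage points higher from compound 3 to compound 4 (beyond the scatter), so this position can carry a 4-hydroxyphenyl group without any loss relative to the best number seen so far. On the same aromatic carbon, hydroxy in place of methyl gives a number 53.4 percentage points higher from compound 2 to compound 4 (beyond the scatter), whereas hydroxy in place of fluoro gives a number 7 percentage points higher from compound 1 to compound 4 (within the scatter). The earlier compounds shown here could not show that a high number here is not tied to fluoro alone: hydroxy and fluoro cannot be told apart in this assay, and methyl is the 4-substituent that stands apart from both. No measurement shown here accounts for these differences.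

The step from compound 3 to compound 4 changes both the substituent and its place on the ring, so a 4-bromophenyl or a 3-hydroxyphenyl group would be needed to separate the two. From the compounds shown here alone, how an amine, a methoxy group or a carboxylic acid on that aromatic carbon would compare with hydroxy and fluoro also remains open.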